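This account rests on a few compounds, and the source may have more. Where it says the series, first, only, none or still open, it means among the compounds named here.

Measured so far:
Compound 1 `CN1CCCN(CCn2ccc3ccc(OCc4ccccc4)cc32)CC1`: 182 nM
Compound 2 `Cc1ccc2ccn(CCN3CCCN(C)CC3)c2c1`: 125 nM

In an assay on HEK293 cells for binding affinity to 5-hydroxytryptamine receptor 7 (Homo sapiens), read by radioligand binding (on this read-out lower numbers stand for stronger inhibition and higher numbers for weaker inhibition), compound 2 gives 125 nM, and compound 1 gives 182 nM. The step between them, a 1.5-fold lower number from compound 1 to compound 2 (0.16 log units; within the scatter), lies within the scatter, so neither compound stands apart from the other. Compound 3 `CC(C)c1ccc2ccn(CCN3CCCN(C)CC3)c2c1` differs from compound 2 by isopropyl in place of methyl on an aromatic carbon. Among the measured compounds shown here, the only measured step, a 1.5-fold lower number from compound 1 to compound 2 (0.16 log units; within the scatter), changed the same aromatic carbon but exchanged benzyloxy for methyl, and it stayed within the scatter; the swap of methyl for isopropyl has no direct precedent here. No step beyond the scatter is therefore expected. Compound 3 is estimated at 150 nM, with a range of 60 nM to 400 nM, meaning an expected step of a 1.2-fold higher number from compound 2 to compound 3 (0.08 log units; within the scatter).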

Compound 3, inhibition constant: 145 nM
Compound 3: middle estimate off by 1.0-fold (0.01 log units), on the high side; low and high end bracket the measured number.
By their numbers in this assay, from the lowest: compounds 2, 3 and 1 (each within the scatter of the next).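

On this aromatic carbon, isopropyl in place of methyl adds two carbons, yet in this assay the number stays within the scatter (a 1.2-fold higher number from compound 2 to compound 3 (0.06 log units; within the scatter)). Isopropyl in place of benzyloxy also stays within it (a 1.3-fold lower number from compound 1 to compound 3 (0.10 log units; within the scatter)), so methyl, isopropyl and benzyloxy on this carbon now give values that cannot be told apart. All three groups carry no hydrogen-bond donors and no net charge. Still open, as far as these compounds go, is whether an amine or a carboxylic acid on this carbon would move the number beyond the scatter. No measurement here gives a reason for these results.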